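The source may report more compounds than this note shows. Statements on the series, on what has been measured and on what is new or still open speak of the compounds shown alone.

Measured so far:
compound 1 `O=C(Nc1c(C(O)(C(F)(F)F)C(F)(F)F)ccc2ccccc12)C1CCCC1` — 495 nM
compound 2 `Cc1ccccc1C(=O)Nc1c(C(O)(C(F)(F)F)C(F)(F)F)ccc2ccccc12` — 5550 nM

In an assay on LtK cells with ATP-sensitive inward rectifier potassium channel 11 (Homo sapiens) as the target (on this read-out higher numbers stand for an effect only at larger amounts of compound and lower numbers for an effect already at smaller amounts), compound 1 gives 495 nM, the lowest of the two numbers, and compound 2 gives 5550 nM. Between them stands one measured step: an 11-fold higher number from compound 1 to compound 2 (1.05 log units; beyond the scatter), where a 2-methylphenyl sits on the carbonyl carbon in place of cyclopentyl.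

Compound 3 `COc1cccc(C(=O)Nc2c(C(O)(C(F)(F)F)C(F)(F)F)ccc3ccccc23)c1` is not yet measured. It differs from compound 1 in this way: 3-methoxyphenyl in place of cyclopentyl on a carbonyl carbon. The step from compound 1 to compound 2 is the only one that bears on this change, since it also exchanges cyclopentyl for a six-membered aromatic ring of carbon only on the carbonyl carbon, and it was large. The ring entering compound 3 carries a methoxy group rather than a methyl group, so the two changes are not identical, and the direction is the best guide. A step to a higher number, beyond the scatter but perhaps smaller than that from compound 1 to compound 2, is expected: a 5.1-fold higher number from compound 1 to compound 3 (0.70 log units; beyond the scatter). For compound 3 the expected value is 2500 nM, estimated to lie between 800 nM and 8000 nM.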

Compound 3, half-maximal effective concentration: 185 nM
Estimate against measurement, compound 3: 14-fold (1.13 log units) above, and the stated range ends above it.
By their numbers in this assay, from the lowest: compound 3; then compound 1; then compound 2.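

In this assay, replacing cyclopentyl with a six-membered aromatic ring on the carbonyl carbon does not always raise the number: the 3-methoxyphenyl group gives a 2.7-fold lower number from compound 1 to compound 3 (0.43 log units; beyond the scatter), the opposite direction to the earlier step with 2-methylphenyl. The choice of aromatic group therefore matters greatly at this position, since exchanging 2-methylphenyl for 3-methoxyphenyl gives a 30-fold lower number from compound 2 to compound 3 (1.48 log units; beyond the scatter), a large step, and among these three compounds the two aromatic groups fall on opposite sides of cyclopentyl. No measurement is available here that accounts for this difference between the two aromatic groups.

These two aromatic groups differ both in the substituent they carry and in where it sits on the ring, so the compounds shown cannot separate those two changes; plain phenyl, 3-methylphenyl and 2-methoxyphenyl would be the natural comparisons. As far as these compounds go, it also remains open how this position responds to quite different groups on the carbonyl carbon, such as a pyridine ring, an amine or a longer carbon chain.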